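Isopropyl for Methyl on the Ring Amine

This account rests on a few compounds, and the source may have more. Where it says the series, first, only, none or still open, it means among the compounds named here.

Among the compounds with values here, compound 1 `CN1Cc2ccc(/C=N/Nc3ncnc4sc(C(C)(C)C)cc34)cc2C1` is the only compound with a number in a functional assay on PC-6 cells (Homo sapiens) for cytotoxicity, read by MTT assay, with a stated time of 3 days (a lower number here means a stronger inhibitor, a higher number a weaker inhibitor), where compound 1 gives 0.05 ug/mL. Compound 2 `COC(=O)c1ccc(/C=N/Nc2ncnc3sc(C(C)(C)C)cc23)cc1` has no result in this assay; for compound 2 the entry reads "not determined" (no result reported). Compound 3 `CC(C)N1Cc2ccc(/C=N/Nc3ncnc4sc(C(C)(C)C)cc34)cc2C1` has not yet been measured in this assay. It differs from compound 1 by isopropyl in place of methyl on an amine nitrogen in a ring. Within the data shown here, no measured pair shows a change of this kind, so the size of the step is uncertain; a step within the scatter, or at most a modest weakening, is expected. Compound 3 is expected to give about 0.08 ug/mL, ranging from 0.02 ug/mL to 0.3 ug/mL. The expected step is a 1.6-fold higher number from compound 1 to compound 3 (0.20 log units; within the scatter).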

Compound 3, half-maximal inhibitory concentration: 0.134 ug/mL
The estimate for compound 3 lay 1.7-fold (0.22 log units) below the measured number, and the stated range covers the measured number.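

In this assay, the amine nitrogen in the ring proves sensitive to the group it carries: isopropyl in place of methyl gives a 2.7-fold higher number from compound 1 to compound 3 (0.43 log units; beyond the scatter) and so a modest but real weakening. Within the data shown here, this single step is the first measured change at this position, and it cannot by itself establish a trend with group size. No data bear on why the number rises. As far as these compounds go, it remains open how the free ring amine, with hydrogen in place of methyl, or a longer chain such as n-butyl would compare with compound 1.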